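The source may report more compounds than this note shows. Statements on the series, on what has been measured and on what is new or still open speak of the compounds shown alone.

Compound 1, `CCCCOC(=O)CNC(=O)[C@H](CSc1ccc([N+](=O)[O-])cc1[N+](=O)[O-])NC(=O)CC[C@H](N)C(=O)OCCCC`: in a toxicity assay on KB cells (Homo sapiens) for cytotoxicity, read by fluorescence, with a stated time of 3 days (on this read-out higher numbers stand for an effect only at larger amounts of compound and lower numbers for an effect already at smaller amounts), compound 1 gives 107 uM.
Compound 2, `CCCCOC(=O)CNC(=O)[C@H](CSc1ccc([N+](=O)[O-])cc1[N+](=O)[O-])NC(=O)CC[C@H](NC(=O)OC(C)(C)C)C(=O)OCCCC`: in this assay compound 2 gives 70.4 uM.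
Compound 3, `CCCCOC(=O)CNC(=O)[C@H](CSc1ccc([N+](=O)[O-])cc1[N+](=O)[O-])NC(=O)CC[C@H](NC(=O)CCc1c[nH]c2ccccc12)C(=O)OCCCC`: in this assay compound 3 gives 26 uM.

Compound 3 stands lowest of the three numbers in this assay, with compound 2 nearest and compound 1 furthest. Compound 4, `CCCCOC(=O)CNC(=O)[C@H](CSc1ccc([N+](=O)[O-])cc1[N+](=O)[O-])NC(=O)CC[C@H](NC(=O)OCc1ccccc1)C(=O)OCCCC`, differs from compound 3 by benzyloxy in place of 2-(1H-indol-3-yl)ethyl on a carbonyl carbon. The step that bears on this is a 2.7-fold lower number from compound 2 to compound 3 (0.43 log units; beyond the scatter), which replaced tert-butoxy on that same carbonyl carbon; a 1.5-fold lower number from compound 1 to compound 2 (0.18 log units; within the scatter) also touched this position but stayed within the scatter. Since benzyloxy, like tert-butoxy, carries an oxygen on the carbonyl carbon, compound 4 is expected to move back toward compound 2, a modest rise in this assay expressed as a 1.7-fold higher number from compound 3 to compound 4 (0.24 log units; within the scatter). Compound 4 is therefore expected to give about 45 uM, within 25 uM to 85 uM.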

Compound 4, concentration for half-maximal effect: 95.2 uM
Compound 4: middle estimate off by 2.1-fold (0.33 log units), on the low side; measured number outside the range, above it.
By their numbers in this assay, from the lowest: compound 3; then compounds 2, 4 and 1 (each within the scatter of the next).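

In this assay the change on this carbonyl carbon gives a 3.7-fold higher number from compound 3 to compound 4 (0.56 log units; beyond the scatter), so the lower number of compound 3 is not shared by every group carrying a six-membered aromatic ring. The other two comparisons, a 1.4-fold higher number from compound 2 to compound 4 (0.13 log units; within the scatter) and a 1.1-fold lower number from compound 1 to compound 4 (0.05 log units; within the scatter), both lie within the scatter, so compound 4 cannot be told apart from compound 2 or compound 1. No evidence is available to explain the gap between compound 3 and compound 4. The compounds shown leave open whether 2-phenylethyl on this carbonyl carbon would match compound 3 without the five-membered ring of its 2-(1H-indol-3-yl)ethyl group.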